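The compounds below may be only part of what the source reports. "The series", "measured", "known", "first", "only" and "open" are said of these compounds alone.

Compound 1, `O=C(CCCCCc1ccc(O)c(F)c1)N1CCOC1=O`, in an assay on HEK293 cells for inhibition of N-acylethanolamine-hydrolyzing acid amidase (Rattus norvegicus), read by LC-MS, with a stated time of 30 min (a higher number here means a weaker inhibitor, a lower number a stronger inhibitor), gives 160 nM.
Compound 2, `O=C1OCCN1C(=O)c1ccc(Oc2ccc(O)cc2)cc1`, in this assay gives > 20000 nM, which is a limit of the assay and not a number.

Compound 2 therefore stands at the limit (the limit of > 20000 nM in this assay, at which 1 of the 2 values shown sits), so only a range is known for it while compound 1 carries a measured number. For the measured compounds named here, no step between measured compounds can be drawn, as the two compounds differ in more than one place.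

Compound 3, `O=C1OCCN1C(=O)c1ccc(OC2CCCC2)cc1`, differs from compound 2 in one place: cyclopentyl in place of 4-hydroxyphenyl on an oxygen on an aromatic ring. With compound 2 sitting at a limit, there is no measured change from which the effect of this swap could be read. The expected step that the limit leaves unreadable from compound 2 to compound 3 is therefore none beyond the scatter, with a strong chance that only a limit will again be reported. Compound 3 is estimated at 25000 nM, with a likely range from 3000 nM to 200000 nM.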

Compound 3, half-maximal inhibitory concentration: 120 nM
Estimate against measurement, compound 3: 210-fold (2.32 log units) above; the whole stated range lies above it.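

On the oxygen on the aromatic ring, cyclopentyl in place of 4-hydroxyphenyl gives an at least 160-fold lower number from compound 2 to compound 3 (2.22 log units; beyond the scatter) in this assay. This shows that the group at this one place can decide whether the compound registers as an inhibitor at all, and that an aromatic ring carrying a hydroxyl is not needed here for a low number, as the cyclopentyl of compound 3 has neither. The size of the step is only a lower bound, as the value for compound 2 is a limit of the assay and not a number: the limit of > 20000 nM in this assay, at which 1 of the 3 values shown sits.

The swap removes the hydroxyl and the aromatic ring together, so the compounds shown leave open which of the two changes matters. A plain phenyl on the same oxygen would separate them, and a cyclohexyl would test the size of the ring.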